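Cyclohexyl to 6-cyanoheptyl on the shared aminopyrimidine core

This account rests on a few compounds, and the source may have more. Where it says the series, first, only, none or still open, it means among the compounds named here.

Compound 1 `CCCc1cnc(-c2nn(Cc3ccccc3F)c3ncccc23)nc1N` gives 252000 nM in a functional assay (aorta) with Oryctolagus cuniculus as the target; a higher number here means a weaker inhibitor, a lower number a stronger inhibitor.
Compound 2 `Nc1nc(-c2nn(Cc3ccccc3F)c3ncccc23)ncc1C1=CCCC1` gives 836000 nM in this assay.
Compound 3 `Nc1nc(-c2nn(Cc3ccccc3F)c3ncccc23)ncc1C1CCCCC1` gives 561000 nM in this assay.

Among these three numbers compound 3 holds the second highest. Its nearest neighbour is compound 2, where a 1.5-fold lower number from compound 2 to compound 3 (0.17 log units; within the scatter), a difference that stays within the scatter. Its furthest neighbour is compound 1, where a 2.2-fold higher number from compound 1 to compound 3 (0.35 log units; beyond the scatter), which lies beyond the scatter.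

The next step changes the group on that aromatic carbon: 6-cyanoheptyl in place of cyclohexyl on an aromatic carbon. The product is compound 4 `CC(C#N)CCCCCc1cnc(-c2nn(Cc3ccccc3F)c3ncccc23)nc1N`.

Going by the values given here, two measured steps bear on this. From the propyl chain of compound 1 to the cyclohexyl ring of compound 3 the number rose, a 2.2-fold higher number from compound 1 to compound 3 (0.35 log units; beyond the scatter); from the same chain to a cyclopent-1-en-1-yl ring it rose more, a 3.3-fold higher number from compound 1 to compound 2 (0.52 log units; beyond the scatter). Both steps went from a chain to a ring and both were modest. Among the compounds with values here, the present step goes the other way, from a ring back to a chain, though a longer one carrying a nitrile, which none of the measured compounds has. The step from compound 3 to compound 4 is therefore expected to be small, toward a lower number, and likely within the scatter, a 1.4-fold lower number from compound 3 to compound 4 (0.15 log units; within the scatter). For compound 4 the estimate in this assay is 400000 nM, with a range from 150000 nM to 1100000 nM.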

Compound 4, half-maximal inhibitory concentration: 1290000 nM
Compound 4: the middle estimate sits 3.2-fold (0.51 log units) below what was measured; the whole stated range lies below it.
By their numbers in this assay, from the lowest: compound 1; then compounds 3, 2 and 4 (each within the scatter of the next, the first and the last beyond it).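

Going back from a ring to a chain at this aromatic carbon did not restore the lower number, as the 6-cyanoheptyl group moved away from the cyclohexyl result (a 2.3-fold higher number from compound 3 to compound 4 (0.36 log units; beyond the scatter)) and further still from the propyl chain (a 5.1-fold higher number from compound 1 to compound 4 (0.71 log units; beyond the scatter)). In this assay, having a chain rather than a ring is therefore not enough for the lower number, and compound 1 remains the strongest of the four, since each of the other three groups gives a step beyond the scatter from its propyl chain; compound 4 and compound 2 cannot be ordered, as their difference stays within the scatter (a 1.5-fold higher number from compound 2 to compound 4 (0.19 log units; within the scatter)). Nothing available explains why the number moves with these groups.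

The change from cyclohexyl to 6-cyanoheptyl alters chain length and adds a nitrile at once, so the four compounds cannot assign the step to either one. A plain heptyl chain would separate those two, while an ethyl group, or a propyl chain ending in an amine or a carboxylic acid, would show how this position responds on the short-chain side.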